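The compounds below may be only part of what the source reports. "The series", "measured", "known", "first", "only" and "open" are said of these compounds alone.

Measured so far in a functional assay on NALM-6 cells (Homo sapiens) for cytotoxicity, read by luminescence and CellTiter-Glo, with a stated time of 3 days; a lower number here means a stronger inhibitor, a higher number a weaker inhibitor:
- Compound 1 `O=C(Nc1ccc(C(F)(F)F)cc1)c1cc(Cl)ccc1O`: 1210 nM
- Compound 2 `O=C(Nc1ccc(C(F)(F)F)cc1)c1cc(Cl)c(-c2ccccc2)cc1O`: 800 nM

Among the measured compounds shown here, only these two compounds have numbers so far. For the measured compounds named here, compound 2 gives 800 nM, but it cannot be ranked apart from compound 1: the single measured step is a 1.5-fold lower number from compound 1 to compound 2 (0.18 log units; within the scatter), with phenyl in place of hydrogen on an aromatic carbon.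

Compound 3 `O=C(Nc1ccc(C(F)(F)F)cc1)c1cc(Br)c(-c2ccccc2)cc1O` keeps the phenyl group and alters one other substituent of compound 2: bromo in place of chloro on an aromatic carbon. Going by the values given here, this is bromo in place of chloro on an aromatic carbon, and no measured pair shows such a swap. Among the compounds with values here, the one step available is a different kind of change, so it bears on the question only indirectly. It offers no direction for the halogen exchange, and it gives no sign of a large response in this assay. No shift beyond the scatter is therefore expected, and the expectation stays anchored on compound 2 at 800 nM. The expected size of the change is a 1.1-fold lower number from compound 2 to compound 3 (0.06 log units; within the scatter). For compound 3 the estimated value is 700 nM, with an expected range from 300 nM to 1500 nM.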

Compound 3, half-maximal inhibitory concentration: 1000 nM
Compound 3: middle estimate off by 1.4-fold (0.15 log units), on the low side; low and high end bracket the measured number.
By their numbers in this assay, from the lowest: compounds 2, 3 and 1 (each within the scatter of the next).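

In this assay, bromo in place of chloro on the aromatic carbon ortho to a phenyl group and para to a hydroxy group gives a 1.3-fold higher number from compound 2 to compound 3 (0.10 log units; within the scatter), so the two halogens cannot be told apart at this position. Among the compounds shown here, this is the first measured look at a change of halogen here, and it adds a second single change that does not separate two compounds, alongside a 1.5-fold lower number from compound 1 to compound 2 (0.18 log units; within the scatter). No measured evidence on the cause of this result is available, and with a step this small there is no effect to explain.

What the compounds shown leave open is whether anything other than a halogen at this position, such as an amine or a carboxylic acid, would move the number beyond the scatter, since only chloro and bromo have been seen there. On these data alone, the trifluoromethyl group and the hydroxy group stand unchanged in all three compounds, so what replacing either of them, for example the hydroxy group with a methoxy group, would do in this assay also remains unknown.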